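The compounds below may be only part of what the source reports. "The series", "measured", "known", "first", "only" and "open" are said of these compounds alone.

Measured in a functional assay on HCT-116 cells (Homo sapiens) for inhibition, read by CCK-8 assay, with a stated time of 48 h; on this read-out lower numbers stand for stronger inhibition and higher numbers for weaker inhibition:
- compound 1 `COc1cc(-c2ccnc3cc(-c4ccc(C)c(C)c4)nn23)cc(OC)c1OC`: 261 nM
- compound 2 `COc1cc(-c2ccnc3cc(-c4cn(C)c5ccccc45)nn23)cc(OC)c1OC`: 762 nM
- compound 3 `COc1cc(-c2ccnc3cc(-c4cccc(C)c4)nn23)cc(OC)c1OC`: 6150 nM

Of these three, compound 3 has the highest number, 6150 nM. Compound 4 `COc1ccc(-c2cc3nccc(-c4cc(OC)c(OC)c(OC)c4)n3n2)cc1N` carries 3-amino-4-methoxyphenyl in place of 3-methylphenyl on an aromatic carbon. The closest measured change is a 24-fold higher number from compound 1 to compound 3 (1.37 log units; beyond the scatter), where 3,4-dimethylphenyl gives way to 3-methylphenyl. Replacing 1-methyl-1H-indol-3-yl also raises the number, an 8.1-fold higher number from compound 2 to compound 3 (0.91 log units; beyond the scatter). Among the compounds with values here, no measured compound has the amino group, so the transfer is uncertain. In this assay, a large step towards a lower number is expected, estimated as a 62-fold lower number from compound 3 to compound 4 (1.79 log units; beyond the scatter). For compound 4 the estimated value is 100 nM, with an expected range of 12 nM to 800 nM.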

Compound 4, half-maximal inhibitory concentration: 251 nM
Compound 4: middle estimate off by 2.5-fold (0.40 log units), on the low side; the measured number falls inside the stated range.
By their numbers in this assay, from the lowest: compounds 4 and 1 (each within the scatter of the next); then compound 2; then compound 3.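

In this assay the aromatic carbon of the five-membered ring accepts a phenyl carrying amino and methoxy groups, with a 25-fold lower number from compound 3 to compound 4 (1.39 log units; beyond the scatter) and a 3.0-fold lower number from compound 2 to compound 4 (0.48 log units; beyond the scatter) in the same direction. Set against 3,4-dimethylphenyl, the change is a 1.0-fold lower number from compound 1 to compound 4 (0.02 log units; within the scatter) and the two substituted phenyl groups stand level, so methyl groups are not the only substituents compatible with numbers in this range.

As far as these compounds go, the separate shares of the amino and methoxy groups stay open, as does the effect of an acetamide or hydroxyl in place of the amino group. No supporting evidence accounts for the size of these steps.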